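The source may hold more compounds than are shown below. What is called first, only, known or untested is meant among the compounds shown, and "the series" means these compounds.

Compound 1 `COc1ccc(/C=N/NC(=O)Nc2ccc(Oc3ccnc(-c4nncn4CCN(C)C)c3)c(F)c2)c(OC)c1` gives 1780 nM in a functional assay on HT-29 cells (Homo sapiens) for cytotoxicity, read by MTT assay, with a stated time of 72 h; on this read-out higher numbers stand for weaker inhibition and lower numbers for stronger inhibition.
Compound 2 `CN(C)CCn1cnnc1-c1cc(Oc2ccc(NC(=O)N/N=C/c3ccccc3O[N+](=O)[O-])cc2F)ccn1` gives 950 nM in this assay.
Compound 3 `CN(C)CCn1cnnc1-c1cc(Oc2ccc(NC(=O)N/N=C/c3cccc(Cl)c3Cl)cc2F)ccn1` gives 130 nM in this assay.

Among these three, compound 3 has the lowest number, and both steps toward it are beyond the scatter: a 14-fold lower number from compound 1 to compound 3 (1.14 log units; beyond the scatter) and a 7.3-fold lower number from compound 2 to compound 3 (0.86 log units; beyond the scatter). The step of a 1.9-fold lower number from compound 1 to compound 2 (0.27 log units; within the scatter) stays within the scatter, so compound 1 and compound 2 cannot be ordered against each other.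

Compound 4 `CN(C)CCn1cnnc1-c1cc(Oc2ccc(NC(=O)N/N=C/c3ccc(F)cc3Cl)cc2F)ccn1` has not yet been measured. It differs from compound 3 in one place: 2-chloro-4-fluorophenyl in place of 2,3-dichlorophenyl on a carbon with a double bond to nitrogen. One chlorine stays, while the other chlorine gives way to a fluorine at a different position on the same ring.

The measured steps bearing on this are those that replaced an oxygen-substituted phenyl with the dichlorophenyl, a 14-fold lower number from compound 1 to compound 3 (1.14 log units; beyond the scatter) and a 7.3-fold lower number from compound 2 to compound 3 (0.86 log units; beyond the scatter); both were large and both lowered the number. Among the measured compounds shown here, no measured pair compares a chloro-fluoro pattern with a dichloro pattern, so the size of the new step rests on analogy only. A halogen-bearing ring remains, so compound 4 is expected to stay closer to compound 3 than to compound 1 or compound 2, with a step of a 1.9-fold higher number from compound 3 to compound 4 (0.28 log units; within the scatter) that may or may not clear the scatter. Compound 4 is estimated at 250 nM, within a range from 80 nM to 800 nM.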

Compound 4, half-maximal inhibitory concentration: 510 nM
Compound 4: middle estimate off by 2.0-fold (0.31 log units), on the low side; low and high end bracket the measured number.
By their numbers in this assay, from the lowest: compound 3; then compounds 4, 2 and 1 (each within the scatter of the next, the first and the last beyond it).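

In this assay the two halogen-bearing rings are not interchangeable at this position: a 3.9-fold higher number from compound 3 to compound 4 (0.59 log units; beyond the scatter) shows that swapping 2,3-dichlorophenyl for 2-chloro-4-fluorophenyl moves the number beyond the scatter, even though one chlorine stays and the heavy-atom count does not change. A halogen on the ring therefore does not by itself bring the low number of compound 3: a 1.9-fold lower number from compound 2 to compound 4 (0.27 log units; within the scatter) leaves compound 4 unordered against the 2-(nitrooxy)phenyl of compound 2, while a 3.5-fold lower number from compound 1 to compound 4 (0.54 log units; beyond the scatter) still separates it from the 2,4-dimethoxyphenyl of compound 1. Nothing available here explains why the two halogen patterns differ.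

Two things change at once in the new step, the second halogen and its place on the ring, and the compounds shown do not separate them. Going by these compounds, a 2,4-dichlorophenyl or a 2,3-difluorophenyl ring would pull those two apart, and how a ring carrying an amine or a carboxylic acid would fare on this carbon also stays open.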